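The source may hold more compounds than are shown below. What is called first, only, known or untested is meant among the compounds shown, and "the series" means these compounds.

Compound 1 `Oc1ccc(C(c2c[nH]c3ccc(Br)cc23)c2c[nH]c3ccc(Br)cc23)cc1`: 4000 nM
Compound 2 `COc1cccc(C(c2c[nH]c3ccc(Br)cc23)c2c[nH]c3ccc(Br)cc23)c1OC`: 64500 nM
Compound 3 `Brc1ccc2[nH]cc(C(c3c[nH]c4ccc(Br)cc34)C3CCCCC3)c2c1`: 3200 nM

All three share one core and differ only in the group on a saturated chain carbon bound to two aromatic carbons. In a functional assay on HeLa cells (Homo sapiens) for inhibition, read by MTT assay, with a stated time of 48 h (on this read-out higher numbers stand for weaker inhibition and lower numbers for stronger inhibition), compound 1 stands second highest of the three numbers: a 1.3-fold lower number from compound 1 to compound 3 (0.10 log units; within the scatter), whereas a 16-fold higher number from compound 1 to compound 2 (1.21 log units; beyond the scatter). Compound 4 `Brc1ccc2[nH]cc(C(c3ccc4ccccc4c3)c3c[nH]c4ccc(Br)cc34)c2c1` has not yet been measured; it differs from compound 1 in one place: naphthalen-2-yl in place of 4-hydroxyphenyl on a saturated chain carbon bound to two aromatic carbons. Both known steps bear on this change, since each also swaps the group at that same carbon. The exchange for cyclohexyl stayed within the scatter, while the exchange for 2,3-dimethoxyphenyl brought a large rise. For compound 4 a modest rise in the number is expected, though not with confidence; the expected step is a 1.5-fold higher number from compound 1 to compound 4 (0.18 log units; within the scatter). Compound 4 is estimated at 6000 nM, in a range from 1500 nM to 25000 nM.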

Compound 4, half-maximal inhibitory concentration: 4300 nM
Compound 4: the middle estimate sits 1.4-fold (0.14 log units) above what was measured; the range from low to high includes it.
By their numbers in this assay, from the lowest: compounds 3, 1 and 4 (each within the scatter of the next); then compound 2.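

In this assay, losing the hydroxyl with its hydrogen-bond donor and gaining a second aromatic ring at this carbon changes little (a 1.1-fold higher number from compound 1 to compound 4 (0.03 log units; within the scatter)). Naphthalen-2-yl also sits level with cyclohexyl (a 1.3-fold higher number from compound 3 to compound 4 (0.13 log units; within the scatter)), so three quite different groups fall within the scatter of one another. Only 2,3-dimethoxyphenyl stands apart (a 15-fold lower number from compound 2 to compound 4 (1.18 log units; beyond the scatter)).

As far as these compounds go, whether an amine or a carboxylic acid on this carbon would fit the same level remains open. Why the dimethoxyphenyl group stands apart also stays unexplained, and no supporting evidence bears on it.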